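A few compounds are considered here, and "the series" means these few. Any claim that something is new, unique, unknown or untested is made for them only; others in the source may bear on it.

In a functional assay on A2780 cells (Homo sapiens) for antiproliferative activity (on this read-out higher numbers stand for weaker inhibition and lower numbers for stronger inhibition), three compounds sharing one core have been measured: compound 1 `CCN1Cc2c(ccc(C)c2C)C(c2ccccc2)C1` gives 5300 nM, compound 2 `Cc1ccc2c(c1C)CN(CCCN)CC2c1ccccc1` gives 2420 nM, and compound 3 `Cc1ccc2c(c1C)CN(CCCN(C)C)CC2c1ccccc1` gives 3240 nM. Compound 3 thus lies within the scatter of both others. Compound 4 `Cc1ccc2c(c1C)CN(CCCCN(C)C)CC2c1ccccc1` differs from compound 3 by (dimethylamino)methyl in place of dimethylamino on a saturated chain carbon, three bonds along the chain from an amine nitrogen in a ring, which takes the chain from 3-(dimethylamino)propyl to 4-(dimethylamino)butyl. The related steps are small: a 1.6-fold lower number from compound 1 to compound 3 (0.21 log units; within the scatter) and a 1.3-fold higher number from compound 2 to compound 3 (0.13 log units; within the scatter) stay within the scatter, while a 2.2-fold lower number from compound 1 to compound 2 (0.34 log units; beyond the scatter) is modest. The change is therefore expected to give no step beyond the scatter in this assay. The estimated step is a 1.1-fold lower number from compound 3 to compound 4 (0.05 log units; within the scatter). For compound 4 the expected value is 2900 nM, with an estimated range of 1400 nM to 6000 nM.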

Compound 4, half-maximal inhibitory concentration: 1860 nM
The estimate for compound 4 lay 1.6-fold (0.19 log units) above the measured number; the range from low to high includes it.
By their numbers in this assay, from the lowest: compounds 4, 2, 3 and 1 (each within the scatter of the next, the first and the last beyond it).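

In this assay, going from 3-(dimethylamino)propyl to 4-(dimethylamino)butyl gives a 1.7-fold lower number from compound 3 to compound 4 (0.24 log units; within the scatter) and so shows that this position accepts the longer chain without a step beyond the scatter. The terminal dimethylamino group on the longer chain also stays close to the shorter primary amine chain, with a 1.3-fold lower number from compound 2 to compound 4 (0.11 log units; within the scatter) as the step. Measured against the shared core without the extended chain, there is a 2.8-fold lower number from compound 1 to compound 4 (0.45 log units; beyond the scatter) as the largest step in this set. Nothing here gives a reason for these steps. From the compounds shown here alone, whether a 5-(dimethylamino)pentyl chain or a terminal piperidine would continue this trend remains open.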